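This account rests on a few compounds, and the source may have more. Where it says the series, first, only, none or still open, it means among the compounds named here.

Measured compounds in a functional assay, tested at 100 ug/mL; a higher number here means a weaker effect of the compound at the concentration tested, a lower number a stronger effect:
- compound 1, `CCOC(=O)C1=C(C)N(c2ccc(Cl)cc2)C=CC1c1ccccc1`, gives -20.8%
- compound 2, `COC(=O)C1=C(C)N(c2ccc(OC)cc2)C=C(C)C1c1ccccc1`, gives -13.9%

Compound 1 and compound 2 differ from each other in more than one place, so no single step can be read between them; what their two numbers show is only that they lie within the usual scatter of each other, and nothing separates compound 2 from compound 1 on this evidence. Both numbers are negative, which in this assay points toward a stronger effect of either compound at the concentration tested.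

Compound 3, `COC(=O)C1=C(C)N(c2cccc(Cl)c2)C=C(C)C1c1ccccc1`, has not yet been measured. It is reached from compound 2 by one change: 3-chlorophenyl in place of 4-methoxyphenyl on an amine nitrogen in a ring. Going by the values given here, no step between measured compounds tells how such a change plays out here, so the expectation rests on the two numbers alone, and the step from compound 2 to compound 3 in this assay is estimated at a number 1.1 percentage points lower from compound 2 to compound 3 (within the scatter), a shift not expected to reach beyond the scatter in either direction. Compound 3 is accordingly expected to give about -15%, with a range from -40% to 10%.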

Compound 3, a percentage reported as activity, at one concentration (the size of the read-out at that concentration, not a potency): -12%
Compound 3: the middle estimate sits 3 percentage points below what was measured; measured number inside the range.
By their numbers in this assay, from the lowest: compounds 1, 2 and 3 (each within the scatter of the next).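

In this assay, going by these compounds alone, the exchange of 4-methoxyphenyl for 3-chlorophenyl on the amine nitrogen in a ring comes out as a number 1.9 percentage points higher from compound 2 to compound 3 (within the scatter) and gives the first step that can be read at a single place in this set. It shows that this position can take a different substituted phenyl, one that also carries no hydrogen-bond acceptor where the group that leaves carries one, without the read-out moving beyond the usual scatter at the concentration tested. No measurement at hand speaks to what lies behind this result.

Because this one step changes both the substituent on the phenyl ring and where it sits on that ring, it cannot show what either change does alone, and the steps to compound 1 cannot be read, since compound 1 differs from the others in more than one place. On these data alone, whether an amine or a carboxylic acid on that phenyl ring, or a longer alkyl chain on the ring nitrogen in place of the phenyl ring, would carry the number beyond the scatter remains open.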